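The compounds below may be only part of what the source reports. "The series", "measured", "known", "first", "only" and "open" are said of these compounds alone.

Measured compounds in this series:

- compound 1, `Cc1nc(S(C)(=O)=O)ccc1Oc1ncnc(OC2CCN(C(=O)OC(C)(C)C(F)(F)F)CC2)c1F`: 6.53 nM
- compound 2, `Cc1nc(S(C)(=O)=O)ccc1Oc1ncnc(OC2CCN(C(=O)OC(C)(C)C#N)CC2)c1F`: 92.9 nM
- compound 3, `Cc1nc(S(C)(=O)=O)ccc1Oc1ncnc(OC2CCN(C(=O)O[C@@H](C)CF)CC2)c1F`: 186 nM

All three were read in a functional assay on isolated protein for inhibition of Glucose-dependent insulinotropic receptor (Homo sapiens), read by HTRF and cAMP accumulation; a lower number here means that less compound is needed, a higher number that more compound is needed for the effect. Compound 2 gives the second highest of the three numbers; its nearest neighbour is compound 3, with a 2.0-fold higher number from compound 2 to compound 3 (0.30 log units; within the scatter), and its furthest is compound 1, with a 14-fold higher number from compound 1 to compound 2 (1.15 log units; beyond the scatter).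

Compound 4, `Cc1nc(S(C)(=O)=O)ccc1Oc1ncnc(OC2CCN(C(=O)O[C@@H](C)C(F)(F)F)CC2)c1F`, is not yet measured. It differs from compound 2 in one place: 1-(trifluoromethyl)ethyl in place of 1-cyano-1-methylethyl on an oxygen next to a carbonyl group.

Going by the values given here, two measured steps bear on this. The step of a 14-fold higher number from compound 1 to compound 2 (1.15 log units; beyond the scatter) shows that exchanging trifluoromethyl for cyano at this saturated chain carbon raised the number strongly; the step from compound 2 to compound 4 runs the other way, restoring trifluoromethyl, though with a hydrogen in place of one methyl, so a full return to the number of compound 1 is not assured. The step of a 2.0-fold higher number from compound 2 to compound 3 (0.30 log units; within the scatter) shows that a smaller fluoroalkyl group here stays within scatter of compound 2. A downward step is therefore expected, smaller than the reverse of the step from compound 1 to compound 2, as a 4.2-fold lower number from compound 2 to compound 4 (0.63 log units; beyond the scatter). Compound 4 is estimated at 22 nM in this assay, with a range from 6 nM to 70 nM.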

Compound 4, half-maximal effective concentration: 9.86 nM
Estimate against measurement, compound 4: 2.2-fold (0.35 log units) above; measured number inside the range.
By their numbers in this assay, from the lowest: compounds 1 and 4 (each within the scatter of the next); then compounds 2 and 3 (each within the scatter of the next).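

In this assay, a 9.4-fold lower number from compound 2 to compound 4 (0.97 log units; beyond the scatter) shows that trifluoromethyl on this saturated chain carbon is tied to the low numbers even with 1-(trifluoromethyl)ethyl in place of the fully substituted group, so the effect is not confined to the 1-methyl-1-(trifluoromethyl)ethyl of compound 1; a 1.5-fold higher number from compound 1 to compound 4 (0.18 log units; within the scatter) leaves the two compounds unseparated, and the extra methyl of compound 1 shows no effect that can be read here. The cleanest reading of the change comes from a 19-fold lower number from compound 3 to compound 4 (1.28 log units; beyond the scatter), where only fluoromethyl gives way to trifluoromethyl on the same carbon, a single exchange that compares in size with the step from nitrile-bearing compound 2 and marks the trifluoromethyl group, not just any fluoroalkyl group, as what separates compounds 1 and 4 from compounds 2 and 3 in this small set. Nothing available explains why trifluoromethyl has this effect on the number.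

Going by these compounds, the opposite configuration at the defined stereocentre of compound 4 remains open. So does whether a longer chain such as pentafluoroethyl, or a cyclopropyl ring carrying trifluoromethyl, on this oxygen would stay within the scatter of compound 4 in this assay.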